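Imidazole substituent at the core carbon of compound 2

A few compounds are considered here, and "the series" means these few. Any claim that something is new, unique, unknown or untested is made for them only; others in the source may bear on it.

Measured so far:
compound 1 `CNc1cc(-n2nc(C(C)C)c3c(-n4cnc(-c5cnn(C)c5)c4)ccnc32)ccc1C(N)=O` 773 nM
compound 2 `COc1cncc(-c2ccnc3c2c(C(C)C)nn3-c2ccc(C(N)=O)c(N[C@H]3CC[C@H](O)CC3)c2)c1` 451 nM

In a functional assay on SK-BR-3 cells (Homo sapiens) for inhibition, read by CellTiter-Glo, with a stated time of 72 h (on this read-out higher numbers stand for weaker inhibition and lower numbers for stronger inhibition), compound 2 gives the lowest of the two numbers, but compound 1 sits within the scatter of it, so no order between them is claimed. Compound 3 `CC(C)c1nn(-c2ccc(C(N)=O)c(N[C@H]3CC[C@H](O)CC3)c2)c2nccc(-n3cnc(-c4ccccc4)c3)c12` differs from compound 2 in one place: 4-phenyl-1H-imidazol-1-yl in place of 5-methoxypyridin-3-yl on an aromatic carbon. Going by the values given here, no measured pair shows this change, so its size is unknown; compound 1, which also carries an imidazol-1-yl at this position, gives 773 nM, which suggests no step beyond the scatter. The estimate a 1.3-fold higher number from compound 2 to compound 3 (0.12 log units; within the scatter) is therefore small, and compound 3 is expected near 600 nM (range 200 nM to 1800 nM).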

Compound 3, half-maximal inhibitory concentration: 276 nM
Estimate against measurement, compound 3: 2.2-fold (0.34 log units) above; measured number inside the range.
By their numbers in this assay, from the lowest: compounds 3, 2 and 1 (each within the scatter of the next, the first and the last beyond it).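

In this assay, going by these compounds alone, this pair is the first direct reading at this position: 4-phenyl-1H-imidazol-1-yl in place of 5-methoxypyridin-3-yl gives a 1.6-fold lower number from compound 2 to compound 3 (0.21 log units; within the scatter). The exchange of a six-membered aromatic ring for an imidazole bearing a carbon-only ring therefore produces no step beyond the scatter. No available measurement bears on why the two groups give such similar numbers.

Compound 1 differs from compound 3 in more than one place, so the contribution of the phenyl group cannot be read. Also open, going by these compounds, is whether an aminomethyl or carboxylic acid group on that phenyl ring would move the number beyond the scatter.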